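The source may hold more compounds than are shown below. What is called first, only, known or untested is meant among the compounds shown, and "the series" means these compounds.

Values measured in a functional assay on PC-3 cells (Homo sapiens) for inhibition, read by MTT assay, with stated times of 18 h and 4 h; a higher number here means a weaker inhibitor, a lower number a stronger inhibitor:
- Compound 1 `CCCCCCCCCCOP(=O)(O)OCCSC(=S)N1CCCC1`: 56100 nM
- Compound 2 `CCCCCCCCCCOP(=O)(O)OCCSC(=S)N1CCCCC1`: 62500 nM
- Compound 3 `CCCOP(=O)(O)OCCSC(=S)N1CCCC1`: > 100000 nM (a limit, not a number)

Only compound 1 and compound 2 have actual numbers here, and they lie within the scatter of each other: a 1.1-fold higher number from compound 1 to compound 2 (0.05 log units; within the scatter). That step swaps one ring group on the thiocarbonyl carbon for another, so it says little about the chain. The value for compound 3 is a limit, as are the limit of > 100000 nM in this assay, at which 1 of the 3 values shown sits.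

The next compound, compound 4 `CCCCCCCCCCCCCCCCOP(=O)(O)OCCSC(=S)N1CCCC1`, differs from compound 1 by hexyl in place of hydrogen on a saturated chain carbon, ten or more bonds along the chain from an oxygen on an unsaturated carbon. The change therefore lies in the chain at the far end of the molecule. For the measured compounds named here, the one measured step that touches this chain runs the opposite way, with hydrogen in place of heptyl: an at least 1.7-fold higher number from compound 1 to compound 3 (0.25 log units; that floor lies within the scatter). It is only a floor, and that floor lies within the scatter, so it gives a direction only weakly and gives no firm size. Lengthening the chain might therefore be expected to give a lower number in this assay, though only modestly and with much uncertainty. The expected step is a 2.2-fold lower number from compound 1 to compound 4 (0.35 log units; beyond the scatter). For compound 4 the estimated value is 25000 nM, with an expected range from 8000 nM to 80000 nM.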

Compound 4, half-maximal inhibitory concentration: 65700 nM
Compound 4: the middle estimate sits 2.6-fold (0.42 log units) below what was measured; the measured number falls inside the stated range.
By their numbers in this assay, from the lowest: compounds 1, 2 and 4 (each within the scatter of the next). At a limit, above all of these: compound 3.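

In this assay, hexyl in place of hydrogen on a saturated chain carbon, ten or more bonds along the chain from an oxygen on an unsaturated carbon, gives a 1.2-fold higher number from compound 1 to compound 4 (0.07 log units; within the scatter). For the compounds shown here, this is the first change to the chain with an actual number on both sides, and it shows that the two compounds cannot be told apart in this assay, so adding hexyl at this place gives no measurable gain or loss. The only other change to the chain ends in a limit rather than a number, and compound 3 therefore still cannot be placed on the same scale: the limit of > 100000 nM in this assay, at which 1 of the 4 values shown sits.

The compounds shown leave open how the value behaves for chains of a length between those of compound 3 and compound 1, and so where along the chain the number gives way to the limit. They also leave open what an amine or a carboxylic acid in place of hexyl on that saturated chain carbon would do, and whether piperidin-1-yl in place of pyrrolidin-1-yl would matter as little on the chain of compound 4.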